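A few compounds are considered here, and "the series" means these few. Any claim that something is new, unique, unknown or untested is made for them only; others in the source may bear on it.

Among the compounds with values here, compound 2 `CC(C)c1ccccc1OS(=O)(=O)c1ccc(NC(=O)C(C)(C)C)cc1` holds the lowest of the two numbers so far recorded in a functional assay on M21 cells (Homo sapiens) for antiproliferative activity, read by sulforhodamine B assay, with a stated time of 48 h (on this read-out lower numbers stand for stronger inhibition and higher numbers for weaker inhibition), where compound 2 gives 6200 nM. Its nearest neighbour is compound 1 `CCC(=O)Nc1ccc(S(=O)(=O)Oc2ccccc2C(C)C)cc1`, which in this assay gives 11000 nM; the step of a 1.8-fold lower number from compound 1 to compound 2 (0.25 log units; within the scatter) lies within the scatter. The next change, (ethylamino in place of tert-butyl on a carbonyl carbon), leads to compound 3 `CCNC(=O)Nc1ccc(S(=O)(=O)Oc2ccccc2C(C)C)cc1`. Within the data shown here, no measured step exchanges a carbon group for an amino group at this carbonyl carbon, so the only guidance is the small step from compound 1 to compound 2. The step of a 1.5-fold higher number from compound 2 to compound 3 (0.16 log units; within the scatter) is therefore expected to stay within the scatter. Compound 3 is estimated at 9000 nM, with a range from 3000 nM to 30000 nM.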

Compound 3, half-maximal inhibitory concentration: 4700 nM
Compound 3: the middle estimate sits 1.9-fold (0.28 log units) above what was measured; the measured number falls inside the stated range.
By their numbers in this assay, from the lowest: compounds 3, 2 and 1 (each within the scatter of the next, the first and the last beyond it).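

In this assay, the exchange to ethylamino on this carbonyl carbon gives different readings depending on the group it replaces. Against tert-butyl, a 1.3-fold lower number from compound 2 to compound 3 (0.12 log units; within the scatter) leaves the two compounds unresolved, whereas against ethyl, a 2.3-fold lower number from compound 1 to compound 3 (0.37 log units; beyond the scatter) gives the only modest step in the set that clears the scatter. From the compounds shown here alone, whether a longer chain on the amino nitrogen, a dimethylamino group or a plain amine at this carbonyl carbon would carry the number further remains open. Nothing at hand accounts for either step.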